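This account rests on a few compounds, and the source may have more. Where it says the series, first, only, none or still open, it means among the compounds named here.

Measured compounds in a functional assay on MCF7 cells (Homo sapiens) for cytotoxicity, read by MTT assay; a higher number here means a weaker inhibitor, a lower number a stronger inhibitor:
- compound 1, `COc1cc(/C=C2\CCC/C(=C\c3ccc([N+](=O)[O-])cc3)C2=O)cc(Br)c1O`: 4.93 ug/mL
- compound 2, `COc1cc(/C=C2\CCC/C(=C\c3ccc([N+](=O)[O-])cc3)C2=O)cc(Br)c1OC`: 11 ug/mL

Compound 2 holds the highest number of the two. Compound 1 sits nearest to it, and the step is a 2.2-fold higher number from compound 1 to compound 2 (0.35 log units; beyond the scatter), a methyl in place of hydrogen on an oxygen on an aromatic ring, modest but beyond the scatter.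

Compound 3, `CCOc1c(Br)cc(/C=C2\CCC/C(=C\c3ccc([N+](=O)[O-])cc3)C2=O)cc1OC`, differs from compound 2 by methyl in place of hydrogen on a saturated chain carbon bound to an oxygen on an aromatic ring. Among the measured compounds shown here, the one measured step that bears on this change is a 2.2-fold higher number from compound 1 to compound 2 (0.35 log units; beyond the scatter): it grows the same oxygen substituent by one carbon and gives a modest rise in this assay. The present change grows it by one further carbon, methyl to ethyl. For the measured compounds named here, no measured pair shows a methyl-to-ethyl step, so the direction is uncertain; the expectation is a step of similar or smaller size, a 1.4-fold higher number from compound 2 to compound 3 (0.13 log units; within the scatter), most likely a slight further rise. Compound 3 is estimated at 15 ug/mL, within 7 ug/mL to 32 ug/mL.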

Compound 3, half-maximal inhibitory concentration: 3.08 ug/mL
The estimate for compound 3 lay 4.9-fold (0.69 log units) above the measured number; measured number outside the range, below it.
By their numbers in this assay, from the lowest: compounds 3 and 1 (each within the scatter of the next); then compound 2.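

In this assay the oxygen substituent shows no single direction with chain size: methoxy to ethoxy gives a 3.6-fold lower number from compound 2 to compound 3 (0.55 log units; beyond the scatter) in this series, opposite in direction to a 2.2-fold higher number from compound 1 to compound 2 (0.35 log units; beyond the scatter) on the same oxygen. Ethyl in place of hydrogen on that oxygen gives a 1.6-fold lower number from compound 1 to compound 3 (0.20 log units; within the scatter) and so leaves the number within the scatter, which makes compound 2 the only one of the three standing apart from the others. No supporting data explain why the methyl ether alone stands apart.

Going by these compounds, whether the lower number holds with a longer chain such as propoxy or butoxy, or with an amine or a carboxylic acid at the end of the chain, remains open. On these data alone, whether the same reversal appears on any other core also remains open.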